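Hydroxyalkyl thioether replaces the amide chain

This account rests on a few compounds, and the source may have more. Where it says the series, first, only, none or still open, it means among the compounds named here.

In a functional assay on HT cells (Homo sapiens) for antiproliferative activity, read by fluorescence, with a stated time of 72 h (a higher number here means a weaker inhibitor of growth, a lower number a stronger inhibitor of growth), compound 2 `CC(C)c1n[nH]c2c(NCc3ccc(-c4ccccn4)cc3)nc(SCCC(N)=O)nc12` gives 120 nM, and compound 1 `CC(C)c1n[nH]c2c(NCc3ccc(-c4ccccn4)cc3)nc(SC(C)C(C)O)nc12` gives 190 nM; the two lie within the scatter of each other. For the measured compounds named here, the single measured step, a 1.6-fold lower number from compound 1 to compound 2 (0.20 log units; within the scatter), traded a hydroxy-bearing chain for an amide chain without moving the number beyond the scatter. Compound 3 `CCC(O)CSc1nc(NCc2ccc(-c3ccccn3)cc2)c2[nH]nc(C(C)C)c2n1` reverses that kind of exchange: 1-hydroxypropyl in place of carbamoylmethyl on a saturated chain carbon bound to a sulfur. Since the related step from compound 1 to compound 2 was within the scatter, no step beyond the scatter is expected for compound 3, so the estimated step is a 1.4-fold higher number from compound 2 to compound 3 (0.15 log units; within the scatter). Compound 3 is therefore expected to give about 170 nM, within a range of 80 nM to 360 nM.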

Compound 3, concentration for 50% growth inhibition: 273 nM
Compound 3: the middle estimate sits 1.6-fold (0.21 log units) below what was measured, within the range that was stated.
By their numbers in this assay, from the lowest: compounds 2, 1 and 3 (each within the scatter of the next, the first and the last beyond it).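

In this assay, for the compounds shown here, the exchange of 2-carbamoylethyl for 2-hydroxybutyl on a sulfur gives a 2.3-fold higher number from compound 2 to compound 3 (0.36 log units; beyond the scatter) and is the first step at this position to pass the scatter. The two hydroxy-bearing chains cannot be told apart, since 2-hydroxybutyl in place of 2-hydroxy-1-methylpropyl gives a 1.4-fold higher number from compound 1 to compound 3 (0.16 log units; within the scatter) and stays within it. Nothing available explains either step. On these data alone, whether an amine, a carboxylic acid or a longer chain on this sulfur would match the amide chain or the hydroxy-bearing chains remains open.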